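Ethoxy in place of trifluoromethyl on the shared core

The source may hold more compounds than are shown below. What is called first, only, known or untested is meant among the compounds shown, and "the series" means these compounds.

In a functional assay on MCF7 cells (Homo sapiens) for antiproliferative activity, read by MTT assay, with a stated time of 72 h (on this read-out lower numbers stand for stronger inhibition and higher numbers for weaker inhibition), compound 1 (`CCOc1ccc(-c2sc(NC)nc2-c2cc(OC)c(OC)c(OC)c2)cc1`) gives 24.5 nM on the read-out. Compound 2 (`COc1cc(-c2nc(C)sc2-c2ccc(C)cc2)cc(OC)c1OC`) gives 1740 nM in the same test. Compound 3 (`COc1cc(-c2nc(C)sc2-c2ccc(C(F)(F)F)cc2)cc(OC)c1OC`) is reported only as a limit (> 10000 nM) of this assay and has no number. Compound 4 (`CCOc1ccc(-c2sc(C)nc2-c2cc(OC)c(OC)c(OC)c2)cc1`) carries ethoxy in place of trifluoromethyl on an aromatic carbon. Among the compounds with values here, the one measured step at this place is an at least 5.7-fold higher number from compound 2 to compound 3 (0.75 log units; beyond the scatter) and it runs toward weaker inhibition. Compound 1 also carries ethoxy and gives 24.5 nM with another group elsewhere on the core. A large estimated step toward lower numbers is therefore expected (an at least 66-fold lower number from compound 3 to compound 4 (1.82 log units; beyond the scatter)). Compound 4 is estimated at 150 nM (range 30 nM to 800 nM).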

Compound 4, half-maximal inhibitory concentration: 42.3 nM
For compound 4 the middle estimate is 3.5-fold (0.55 log units) above the measured one, within the range that was stated.
By their numbers in this assay, from the lowest: compounds 1 and 4 (each within the scatter of the next); then compound 2. At a limit, above all of these: compound 3.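

At the aromatic carbon para to a large group, ethoxy sets itself far apart from both smaller-numbered comparisons in this assay: against methyl the result is a 41-fold lower number from compound 2 to compound 4 (1.61 log units; beyond the scatter), and against trifluoromethyl it is an at least 230-fold lower number from compound 3 to compound 4 (2.37 log units; beyond the scatter). That second step is only a bound, and compound 3 is a limit and not a number: the limit of > 10000 nM in this assay, at which 1 of the 4 values shown sits. With ethoxy in place, methyl and methylamino elsewhere on the core do not separate, at a 1.7-fold higher number from compound 1 to compound 4 (0.24 log units; within the scatter).

From the compounds shown here alone, how methoxy, a longer alkoxy chain or an amine would read at this place stays open. So does whether methylamino would change the number of compound 2.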